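Removing the chain methyl from compound 1: rat microsomal clearance

A few compounds are considered here, and "the series" means these few. Any claim that something is new, unique, unknown or untested is made for them only; others in the source may bear on it.

- compound 1 `CC(Oc1nn(-c2ccccc2F)c2ccc(F)cc12)C(=O)N1CCOCC1` gives 717 mL/min/kg
- compound 2 `O=C1NCCN1CCOc1nn(-c2ccc(F)cc2F)c2ccc(F)cc12` gives 617 mL/min/kg
- compound 3 `CC(C)(C)OC(=O)N1CCN(c2cccc3c2cnn3-c2ccccc2F)C1=O` gives 120 mL/min/kg

All three values come from an ADME assay on liver for metabolic stability, with Liver microsome (Rattus norvegicus) as the target, using microsomes and NADPH, with a stated time of 30 min, tested at 0.5 uM (on this read-out higher numbers stand for fast clearance and lower numbers for slow clearance), and span a wide range. Compound 1 holds the highest number of the three, but compound 2 lies within the scatter of it, so the two cannot be separated. Compound 3 is lower than compound 1 by a margin beyond the scatter.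

The next compound to be read is compound 4 `O=C(COc1nn(-c2ccccc2F)c2ccc(F)cc12)N1CCOCC1`, which differs from compound 1 by a single change (hydrogen in place of methyl on a saturated chain carbon bound to a carbonyl carbon and an oxygen on an aromatic ring): hydrogen in place of methyl on a saturated chain carbon bound to a carbonyl carbon and an oxygen on an aromatic ring.

For the measured compounds named here, no measured pair isolates this change, so its size in this assay has no direct precedent. Compound 2 also has no methyl on that chain carbon and gives 617 mL/min/kg in spite of its other differences, which offers only indirect support for a high number without the methyl. A small drop, or none beyond the scatter, is therefore expected. The estimate means a 1.2-fold lower number from compound 1 to compound 4 (0.08 log units; within the scatter) and so a step within the scatter. For compound 4 the expected clearance is 600 mL/min/kg with an estimated range from 300 mL/min/kg to 1000 mL/min/kg.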

Compound 4, clearance: 183 mL/min/kg
Estimate against measurement, compound 4: 3.3-fold (0.52 log units) above; the whole stated range lies above it.
By their numbers in this assay, from the lowest: compounds 3 and 4 (each within the scatter of the next); then compounds 2 and 1 (each within the scatter of the next).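

In this assay, for the compounds shown here, this is the first pair that isolates a single change: hydrogen in place of methyl on a saturated chain carbon bound to a carbonyl carbon and an oxygen on an aromatic ring gives a 3.9-fold lower number from compound 1 to compound 4 (0.59 log units; beyond the scatter) and thus shows that the read-out responds to this position. The change removes one carbon and no hydrogen-bond donor or acceptor, no ring and no net charge. The rest of the structure is held constant, and the difference lies beyond the scatter. Nothing available here accounts for the size of this step, and the mechanism behind it remains unaddressed.

The series as shown holds only this one pair for the position, so whether the step would recur on a different core or with a different amide remains open. Also open, on these data alone, is how this assay would read with other groups on this chain carbon, such as an ethyl, a second methyl, a fluorine or a hydroxyl.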